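From nitro to acetyl on the shared core

The source may report more compounds than this note shows. Statements on the series, on what has been measured and on what is new or still open speak of the compounds shown alone.

compound 1 `CCC(=O)N(c1ccc(C)cc1)C1CCCC1N(C)C` gives 30 mg/kg; 30 mg/kg (2 entries)
compound 2 `CCC(=O)N(c1ccc(Br)cc1)C1CCCC1N(C)C` gives 2 mg/kg
compound 3 `CCC(=O)N(c1ccc([N+](=O)[O-])cc1)C1CCCC1N(C)C` gives 20 mg/kg

In a functional assay on the whole organism for positive allosteric modulation, with Mus musculus as the target (on this read-out lower numbers stand for an effect already at smaller amounts and higher numbers for an effect only at larger amounts of compound), compound 3 stands at 20 mg/kg and holds the higher of the two numbers that come from a single entry, while compound 1 has two entries. Compound 4 `CCC(=O)N(c1ccc(C(C)=O)cc1)C1CCCC1N(C)C` has not been measured yet and carries acetyl in place of nitro on an aromatic carbon. For the measured compounds named here, the one measured step that involves nitro is a 10-fold higher number from compound 2 to compound 3 (1.00 log units; beyond the scatter) and it shows that a swap at this place can move the number well beyond the scatter. Going by the values given here, no measured step involves acetyl, so that single step gives no direction for this swap and only argues for a wide range. What is expected, then, is no step beyond the scatter (a 1.3-fold lower number from compound 3 to compound 4 (0.12 log units; within the scatter)). For compound 4 the estimated value is 15 mg/kg with an expected range from 4 mg/kg to 50 mg/kg (an estimate, not a measurement).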

Compound 4, dose for half-maximal effect: > 50 mg/kg
Compound 4 was reported as a limit (the forecaster's own chance of this, stated with the estimate: 3%); middle value at least 3.3-fold (0.52 log units) from the limit.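

In this assay, compound 4 is reported only as a limit, not as a single number: the limit of > 50 mg/kg in this assay, at which 1 of the 4 values shown sits. Even so, the direction can be read, with acetyl in place of nitro giving an at least 2.5-fold higher number from compound 3 to compound 4 (0.39 log units; beyond the scatter), and acetyl in place of bromo giving an at least 25-fold higher number from compound 2 to compound 4 (1.39 log units; beyond the scatter). Nitro and acetyl have the same count of heavy atoms, so this place on the aromatic ring separates two groups that this count alone cannot tell apart, and bromo keeps the lowest number of the three groups linked by these steps.

From the compounds shown here alone, how far compound 4 lies past its limit stays open, so both steps give only a smallest size. Also open, going by these compounds, is whether chloro, an amine or a carboxylic acid on this aromatic carbon would sit closer to bromo or to acetyl.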